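Hydroxy to Methoxy Step in Two Related Cores

This account rests on a few compounds, and the source may have more. Where it says the series, first, only, none or still open, it means among the compounds named here.

Measured compounds:
compound 1, `COc1cc(C[C@H]2COC(=O)[C@@H]2Cc2ccc(Cl)c(Cl)c2)ccc1O`: 36000 nM
compound 2, `COc1ccc(C[C@H]2COC(=O)[C@@H]2Cc2ccc(Cl)c(Cl)c2)cc1OC`: 24000 nM
compound 3, `Oc1cccc(C[C@H]2COC[C@@H]2Cc2ccc(Cl)c(Cl)c2)c1`: 31000 nM

All three numbers come from a functional assay on HL-60 cells (Homo sapiens) for cytotoxicity, read by WST assay, with a stated time of 48 h; a higher number here means that more compound is needed for the effect, a lower number that less compound is needed. The three values lie close together, and none of the gaps between them is beyond the scatter, so no ordering among compound 1, compound 2 and compound 3 is claimed.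

Compound 1 and compound 2 share one core and differ in a single place: methyl in place of hydrogen on an oxygen on an aromatic ring. The step that goes with it is a 1.5-fold lower number from compound 1 to compound 2 (0.18 log units; within the scatter), so the methylation as such left the number essentially where it was.

Compound 3 has a different core; how its core differs from that of compound 1 is not broken down here, and the two are compared only by their values, which sit within the scatter of each other.

Compound 4, `COc1cccc(C[C@H]2COC[C@@H]2Cc2ccc(Cl)c(Cl)c2)c1`, is not yet measured. It differs from compound 3 by methyl in place of hydrogen on an oxygen on an aromatic ring, the same change that was made from compound 1 to compound 2, at a place described in the same words in both cases. The expectation for compound 4 therefore rests on the step seen from compound 1 to compound 2, a 1.5-fold lower number from compound 1 to compound 2 (0.18 log units; within the scatter), and is an expected step of a 1.3-fold lower number from compound 3 to compound 4 (0.11 log units; within the scatter). On that basis compound 4 is estimated at 24000 nM in this assay, with a range from 9000 nM to 60000 nM.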

Compound 4, half-maximal effective concentration: 73000 nM
Compound 4: middle estimate off by 3.0-fold (0.48 log units), on the low side, outside the stated range (above it).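

In this assay, methyl in place of hydrogen on an oxygen on an aromatic ring gives a 2.4-fold higher number from compound 3 to compound 4 (0.37 log units; beyond the scatter), a modest step on the core of compound 3. Set beside the same change on the core of compound 1, the step does not repeat: the same change on two cores in this assay, a 1.5-fold lower number (0.18 log units; within the scatter) from compound 1 to compound 2 and a 2.4-fold higher number (0.37 log units; beyond the scatter) from compound 3 to compound 4, 3.5-fold (0.55 log units) apart, beyond the scatter of two such steps. This shows that, in these two pairs, the size and direction of the hydroxy to methoxy step do not carry from one core to the other, so a step read on one core is a poor guide to the same change on the other; it does not show which difference between the cores is responsible, and two pairs are too few to support a rule for the wider series.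

Still open, as far as these compounds go, is whether the step on the core of compound 3 is specific to methyl or would extend to an ethyl group or a longer chain on the same oxygen. Also open, from the compounds shown here alone, is how an amine or a carboxylic acid in place of the hydroxy would behave on each of the two cores, and whether either core would then respond as the other does.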